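The source may hold more compounds than are shown below. What is called first, only, known or untested is meant among the compounds shown, and "the series" means these compounds.

Compound 1 `CCNC(=O)Nc1sc2ccccc2c1C(=O)N1CCN(C2CCN(C(C)=O)CC2)CC1` carries an acetyl group on a carbonyl carbon whose other neighbour is an amide-type nitrogen in a ring. In a functional assay on HepG2 cells (Homo sapiens) for inhibition, read by scintillation counting, with a stated time of 2 h (on this read-out higher numbers stand for weaker inhibition and lower numbers for stronger inhibition), compound 1 gives "not determined" (no result reported), that is, no result was reported, so it has no number to stand on. A close relative, compound 2 `CCNC(=O)Nc1sc2ccccc2c1C(=O)N1CCN(C2CCN(C(=O)C3CCCC3)CC2)CC1`, differs from it only at that carbonyl carbon, and in this assay compound 2 gives 309 nM. Compound 3 `CCNC(=O)Nc1sc2ccccc2c1C(=O)N1CCN(C2CCN(C(=O)C3CCCCC3)CC2)CC1` has not yet been measured. It differs from compound 1 in one place: cyclohexyl in place of methyl on a carbonyl carbon. With compound 1 unmeasured, the step from compound 1 to compound 3 cannot be sized from the data; taking compound 2 at 309 nM as the nearest anchor, the change is expected to move the reading little, most likely staying within the scatter in this assay. Compound 3 is therefore estimated to give about 300 nM, within a range from 100 nM to 1000 nM.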

Compound 3, half-maximal inhibitory concentration: 146 nM
Beside the measured number, compound 3's estimate is 2.1-fold (0.31 log units) above it, and the stated range covers the measured number.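

In this assay the exchange of cyclopentyl for cyclohexyl on a carbonyl carbon gives a 2.1-fold lower number from compound 2 to compound 3 (0.33 log units; beyond the scatter) and so shows that this position responds, modestly, to a change of one carbocyclic ring for another. On these data alone, compound 1 has no number, so the step from its methyl to cyclohexyl cannot be read, and what either ring gains over acetyl remains unknown. Nothing available explains the difference between the two rings.

As far as these compounds go, two ring sizes do not establish a trend, so it remains open whether cycloheptyl or phenyl on the same carbonyl carbon would extend this step or reverse it. Also open, from the compounds shown here alone, is how the reading would respond to a ring or chain carrying an amine or a carboxylic acid in place of cyclohexyl.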